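The source may report more compounds than this note shows. Statements on the series, on what has been measured and on what is new or still open speak of the compounds shown alone.

Measured so far:
Compound 1 `CCc1ccc(Cn2c(=O)nc(NCCNC(=N)N)n(Cc3ccc(OC)cc3)c2=O)cc1` gives 0.0058 nM in a functional assay on the whole organism (strain C57Bl/6) for inhibition, with Mus musculus as the target, with a stated time of 180 min, at 48 degrees C; a lower number here means that less compound is needed, a higher number that more compound is needed for the effect.
Compound 2 `COc1ccc(Cn2c(=O)nc(NCCNC(=N)N)n(Cc3ccc(C(F)(F)F)cc3)c2=O)cc1` gives 0.048 nM in this assay.

Of these two numbers, compound 1 has the lowest, so it needs the least compound for the effect; compound 2 sits a clear step higher, beyond the usual scatter. Compound 3 `COc1ccc(Cn2c(NCCNC(=N)N)nc(=O)n(Cc3ccc([N+](=O)[O-])cc3)c2=O)cc1` has not been measured. It differs from compound 1 in one place: nitro in place of ethyl on an aromatic carbon. Among the compounds with values here, no measured pair shows this exact change, so the direction can only be guessed from what compound 2 shows, where a trifluoromethyl on the corresponding ring goes with the higher number. A step upward, of a size similar to that seen between compound 1 and compound 2, seems the most likely outcome, though it could also stay within the scatter. For compound 3 the expected value is therefore 0.04 nM, in a range from 0.008 nM to 0.2 nM, which would mean a step of a 6.9-fold higher number from compound 1 to compound 3 (0.84 log units; beyond the scatter) as the estimate.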

Compound 3, half-maximal effective concentration: 0.048 nM
Beside the measured number, compound 3's estimate is 1.2-fold (0.08 log units) below it; measured number inside the range.
By their numbers in this assay, from the lowest: compound 1; then compounds 2 and 3 (each within the scatter of the next).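

Within the data shown here, this is the first comparison here in which only one place changes, so the effect of the group on this benzyl ring can be read directly. In this assay, exchanging 4-ethylbenzyl for 4-nitrobenzyl, with the rest of the molecule unchanged, gives an 8.3-fold higher number from compound 1 to compound 3 (0.92 log units; beyond the scatter), a modest step but a real one, and the ethyl compound needs less compound for the effect. Nothing measured here explains why this step occurs.

A single pair cannot show whether the numbers at this position follow any trend across groups. Going by these compounds, how an amine, a carboxylic acid or a longer chain such as propyl would fare in this same place remains open, as does whether the same exchange would give a similar step on a different version of the core.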